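Trading a Nitrile for an Ester in a Cytotoxicity Series

This account rests on a few compounds, and the source may have more. Where it says the series, first, only, none or still open, it means among the compounds named here.

Of the compounds shown here, three built on one shared core have been tested in a functional assay on MCF7 cells (Homo sapiens) for cytotoxicity, read by MTT assay, with a stated time of 3 days; on this read-out lower numbers stand for stronger inhibition and higher numbers for weaker inhibition. Compound 1 `Cc1ccc2nc(C)n(NC(=O)CC#N)c(=O)c2c1` gives 40000 nM in this assay. Compound 2 `Cc1ccc2nc(C)n(-n3c(O)cc(N)c(C#N)c3=O)c(=O)c2c1` gives 26000 nM. Compound 3 `Cc1ccc2nc(C)n(-n3c(N)c(C#N)c(-c4ccccc4)c(C#N)c3=O)c(=O)c2c1` gives 8000 nM, the lowest of the three numbers; its gaps to compound 2 and to compound 1 both lie beyond the scatter, so compound 3 is the most potent of the measured set.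

Compound 4 `CCOC(=O)c1c(-c2ccccc2)c(C#N)c(=O)n(-n2c(C)nc3ccc(C)cc3c2=O)c1N` has not yet been measured. It differs from compound 3 in a single place: ethoxycarbonyl in place of cyano on an aromatic carbon. No measured pair in this series shows that exchange, so there is no measured step to draw on, and the three values shown give no reason to expect a large shift in either direction. The step from compound 3 to compound 4 in this assay is expected to be a 1.1-fold higher number from compound 3 to compound 4 (0.05 log units; within the scatter), none beyond the scatter. Compound 4 is therefore estimated to give 9000 nM in this assay, with a range from 3000 nM to 27000 nM.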

Compound 4, half-maximal inhibitory concentration: 17000 nM
Compound 4: middle estimate off by 1.9-fold (0.28 log units), on the low side; the measured number falls inside the stated range.
By their numbers in this assay, from the lowest: compound 3; then compounds 4, 2 and 1 (each within the scatter of the next, the first and the last beyond it).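

In this assay the exchange of cyano for ethoxycarbonyl on this aromatic carbon, ortho to a phenyl group and ortho to an amino group, gives a 2.1-fold higher number from compound 3 to compound 4 (0.33 log units; beyond the scatter) and so shows that this position responds to the change, in the direction of weaker inhibition. Going by these compounds alone, this modest step is the first reading of a single exchange, since the earlier compounds differ from one another in more than one place. Nothing at hand bears on why the number moves in this way.

As far as these compounds go, it remains open whether a carboxylic acid or a primary amide on this carbon would stay with the nitrile or with the ester. Also open, from the compounds shown here alone, is whether the same exchange at the remaining cyano group, meta to this position, would give a similar step.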